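Phenyl for Methyl on a Core Without Measurable Activity

This account rests on a few compounds, and the source may have more. Where it says the series, first, only, none or still open, it means among the compounds named here.

Compound 2 `Cc1oc2c3c(ccc2c(=O)c1C)OC[C@H]1[C@@H]3C2=C(CC(C)(C)CC2=O)OC1(C)C`, compound 1 `Cc1oc2c3c(ccc2c(=O)c1C)OC[C@H]1[C@@H]3C2=C(CCCC2=O)OC1(C)C` and compound 3 `Cc1coc2c3c(ccc2c1=O)OC[C@H]1[C@@H]3C2=C(CC(C)(C)CC2=O)OC1(C)C` share one core and were tested in a functional assay on SK-N-SH cells (Homo sapiens) for antiproliferative activity, read by MTT assay, with a stated time of 48 h; a lower number here means a stronger inhibitor, a higher number a weaker inhibitor. Compound 2 gives only a limit, > 100000 nM. Compound 1 likewise gives a limit, > 100000 nM. Compound 3 also gives a limit, > 100000 nM. For the measured compounds named here, the one step between measured compounds, a step that the two limits leave unreadable from compound 2 to compound 3, therefore cannot be sized; all three sit at the limit of > 100000 nM in this assay, at which 3 of the 3 values shown sit. Compound 4 `Cc1oc2c3c(ccc2c(=O)c1-c1ccccc1)OC[C@H]1[C@@H]3C2=C(CC(C)(C)CC2=O)OC1(C)C` differs from compound 2 by phenyl in place of methyl on an aromatic carbon. Going by the values given here, no measured step bears on this change; the single step available concerns a different group and stays unreadable. With nothing to move compound 4 away from the limit, its value is expected to remain near it, an estimate of 100000 nM with a range from 30000 nM to 300000 nM. The step this estimate implies, a number no higher from compound 2 to compound 4 (the limit leaves the size open), is expected to stay within the scatter.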

Compound 4, half-maximal inhibitory concentration: > 100000 nM
Compound 4 gave a limit, no number; the forecaster's own chance of this, stated with the estimate: 80%; the middle value lies on the limit itself.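

Compound 2 and compound 4 both give only a limit, so no step between them can be read: the limit of > 100000 nM in this assay, at which 4 of the 4 values shown sit.

The compounds shown leave open which change to the shared core, if any, would give a measurable value.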